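Trading a Furan Ring for a Methoxypyridine on a Shared Core

The source may report more compounds than this note shows. Statements on the series, on what has been measured and on what is new or still open speak of the compounds shown alone.

Compound 1 `O=C(O)Cc1sc(C(c2ccc(F)cc2)c2ccc(F)cc2)nc1-c1ccccc1` carries a phenyl ring on its core, and in an in vitro functional assay on HEK285-7 cells for antagonist activity at prostaglandin D2 receptor 2 (Homo sapiens), read by BRET and beta-arrestin recruitment (on this read-out higher numbers stand for weaker inhibition and lower numbers for stronger inhibition), compound 1 gives 240 nM. Compound 2 `O=C(O)Cc1sc(C(c2ccc(F)cc2)c2ccc(F)cc2)nc1-c1ccoc1` differs only in having a furan-3-yl ring in that place, and in this assay compound 2 gives 130 nM. The step of a 1.8-fold lower number from compound 1 to compound 2 (0.27 log units; within the scatter) lies within the scatter, so compound 2 holds the lowest of the two numbers but cannot be told apart from compound 1 with confidence.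

Compound 3 `COc1cc(-c2nc(C(c3ccc(F)cc3)c3ccc(F)cc3)sc2CC(=O)O)ccn1` is the next compound to be measured. The change is 2-methoxypyridin-4-yl in place of furan-3-yl on an aromatic carbon. Going by the values given here, the only measured step that bears on this, the exchange of one aromatic ring for another at the same position, is a 1.8-fold lower number from compound 1 to compound 2 (0.27 log units; within the scatter), which stayed within the scatter. On that basis, swapping the furan-3-yl ring for a 2-methoxypyridin-4-yl ring is expected to give a step of a 1.2-fold higher number from compound 2 to compound 3 (0.06 log units; within the scatter), that is, no change beyond the scatter. Compound 3 is therefore estimated at 150 nM, with a likely range from 50 nM to 450 nM.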

Compound 3, half-maximal inhibitory concentration: 380 nM
Compound 3: middle estimate off by 2.5-fold (0.40 log units), on the low side, within the range that was stated.
By their numbers in this assay, from the lowest: compounds 2, 1 and 3 (each within the scatter of the next, the first and the last beyond it).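

In this assay, going by these compounds alone, the exchange of one aromatic ring for another on this carbon now gives a 2.9-fold higher number from compound 2 to compound 3 (0.47 log units; beyond the scatter) as the first step beyond the scatter, so the choice of ring here can shift the number by a measurable amount. The comparison with the phenyl ring gives a 1.6-fold higher number from compound 1 to compound 3 (0.20 log units; within the scatter) and stays within the scatter, so the furan-3-yl and 2-methoxypyridin-4-yl rings stand apart, while the phenyl ring cannot be separated from either of them. Nothing measured here gives a reason for the step from the five-membered furan-3-yl ring to the larger six-membered 2-methoxypyridin-4-yl ring.

The 2-methoxypyridin-4-yl ring brings in a ring nitrogen and a methoxy group together, and a plain pyridin-4-yl ring and a 3-methoxyphenyl ring would be needed to show what each contributes alone. Also open, from the compounds shown here alone, is whether a non-aromatic group on this carbon, such as a cyclopropyl ring or an amine, would keep the number close to those of the aromatic rings.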